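A few compounds are considered here, and "the series" means these few. Any claim that something is new, unique, unknown or untested is made for them only; others in the source may bear on it.

Series notes, the step from compound 2 to compound 3.

Compound 1, `CCCCn1nc(C(=O)N[C@H]2COc3ccccc3N(C)C2=S)nc1Cc1ccccc1`, is measured in a toxicity assay on HT-29 cells (Homo sapiens) for cytotoxicity; a higher number here means that more compound is tolerated, a lower number that less compound is tolerated. In this assay compound 1 gives > 100000 nM, which is a limit of the assay and not a number. Compound 2, `CN1C(=S)[C@@H](NC(=O)c2nc(Cc3ccccc3)n(CCC(F)(F)F)n2)COc2ccccc21`, in this assay gives > 100000 nM, again a limit of the assay rather than a number. The step that the two limits leave unreadable from compound 1 to compound 2 is therefore of unreadable size, since both values sit at the limit of > 100000 nM in this assay, at which 2 of the 2 values shown sit.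

Compound 3, `CN1C(=S)[C@@H](NC(=O)c2nc(Cc3ccccc3)n(C3CCCCC3)n2)COc2ccccc21`, is not yet measured. It differs from compound 2 by cyclohexyl in place of 3,3,3-trifluoropropyl on an aromatic nitrogen. Among the measured compounds shown here, only the step from compound 1 to compound 2 bears on this change, and it gives no readable size; both compounds tolerate the compound up to the limit. No step beyond the scatter is therefore expected in this assay, a number no higher from compound 2 to compound 3 (the limit leaves the size open). Compound 3 is expected to show 100000 nM in this assay, within 30000 nM to 300000 nM, most likely again reported as a limit.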

Compound 3, half-maximal cytotoxic concentration: > 100000 nM
Compound 3 was reported as a limit (the forecaster's own chance of this, stated with the estimate: 80%); the middle value sits exactly at the limit.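

No step can be read among compound 1, compound 2 and compound 3 in this assay, where each value is a limit of the assay and not a number: the limit of > 100000 nM in this assay, at which 3 of the 3 values shown sit.

The compounds shown leave open whether butyl, 3,3,3-trifluoropropyl and cyclohexyl on the aromatic nitrogen differ at all in this assay.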